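This account rests on a few compounds, and the source may have more. Where it says the series, first, only, none or still open, it means among the compounds named here.

Working notes on the series. In an assay on microsomes from brain for inhibition of Fatty-acid amide hydrolase 1 (Rattus norvegicus), read by HPLC, with a stated time of 60 min (on this read-out higher numbers stand for weaker inhibition and lower numbers for stronger inhibition), compound 1 `O=C(Oc1ccccc1)N1CCC(CCn2ccc3cc(Cl)ccc32)CC1` gives 410 nM. Compound 3 `O=C(Oc1ccccc1)N1CCC(CCCn2ccc3ccccc32)CC1` gives 570 nM in this assay, a number within the scatter of that of compound 1. Within the data shown here, compound 2 `O=C(Oc1ccccc1)N1CCC(CCn2ccc3ccc(F)cc32)CC1` gives 46 nM in this assay, a lower number than compound 1 by a gap beyond the scatter; compound 2 is the only compound of the three to separate clearly from the other two.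

Compound 4 `COc1ccc2c(ccn2CCC2CCN(C(=O)Oc3ccccc3)CC2)c1` is not yet measured in this assay. It differs from compound 1 in one place: methoxy in place of chloro on an aromatic carbon. Among the measured compounds shown here, no measured pair makes this same change, so no step can be read off. The step of a 1.4-fold lower number from compound 1 to compound 4 (0.14 log units; within the scatter) is expected to be small, in either direction or none beyond the scatter. Compound 4 is therefore estimated at 300 nM in this assay, with a range from 70 nM to 1300 nM.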

Compound 4, half-maximal inhibitory concentration: 360 nM
Beside the measured number, compound 4's estimate is 1.2-fold (0.08 log units) below it; the range from low to high includes it.
By their numbers in this assay, from the lowest: compound 2; then compounds 4, 1 and 3 (each within the scatter of the next).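

In this assay, methoxy in place of chloro on an aromatic carbon gives a 1.1-fold lower number from compound 1 to compound 4 (0.06 log units; within the scatter). Among these compounds, at this position of the six-membered aromatic ring, the change from chloro to methoxy, with its 2 heavy atoms and 1 hydrogen-bond acceptor, thus leaves the number within the scatter, which the earlier compounds could not show. Nothing available gives a reason for this result.

The compounds shown leave open how the unsubstituted core compares with chloro and methoxy at this position. Also open, on these data alone, is whether an amine or a carboxylic acid here would stay within the scatter of compound 1.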